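Benzyl for isobutyl on the aryl ether oxygen

The source may hold more compounds than are shown below. What is called first, only, known or untested is meant among the compounds shown, and "the series" means these compounds.

Measured so far in a functional assay on P388 cells (Mus musculus) for cytotoxicity; a higher number here means that more compound is needed for the effect, a lower number that less compound is needed:

compound 1, `CC(C)COc1cc(-c2ccccc2)nc2ccccc12`: this assay gives only a limit, > 10 ug/mL.
compound 2, `Oc1cc(-c2ccccc2)nc2cc(F)ccc12`: 0.29 ug/mL.
compound 3, `Oc1cc(-c2ccccc2)nc2c(F)cccc12`: 0.67 ug/mL.

Compound 1 is the only ether among the three and its value is a limit of this assay, not a number; it sits at the limit of > 10 ug/mL in this assay, at which 1 of the 3 values shown sits. For the measured compounds named here, compounds 2 and 3 carry a free hydroxyl on the shared core together with a ring fluorine, and both give numbers well under the limit, but neither differs from compound 1 in one place only, so no step to them can be read.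

The unmeasured compound 4, `c1ccc(COc2cc(-c3ccccc3)nc3ccccc23)cc1`, is reached from compound 1 by phenyl in place of isopropyl on a saturated chain carbon bound to an oxygen on an aromatic ring. Going by the values given here, no measured step of this kind exists in the set, so its size and direction are unknown. The ether oxygen stays blocked as in compound 1, and compound 1 gives only a limit; the step that the limit leaves unreadable from compound 1 to compound 4 is therefore expected to be small, with no direction claimed beyond the scatter. Compound 4 is estimated at 15 ug/mL, within 3 ug/mL to 60 ug/mL, most likely again reported as a limit.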

Compound 4, half-maximal effective concentration: > 10 ug/mL
Compound 4: no number, only a limit (the forecaster's own chance of this, stated with the estimate: 70%); the middle value is on the limit's open side.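

Compound 1 and compound 4 each give only a limit in this assay, so no step between them can be read: the limit of > 10 ug/mL in this assay, at which 2 of the 4 values shown sit.

The compounds shown leave open what size or direction the change from isobutoxy to benzyloxy has, and whether any ether on the shared core gives a number in this assay.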